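The compounds below may be only part of what the source reports. "The series", "measured", "known", "first", "only" and "open" are said of these compounds alone.

Compound 1 `CCCCCSC[C@H](NC(C)=O)C(=O)CCl` and compound 2 `CCCCCCCCCCCCCSC[C@H](NC(C)=O)C(=O)CCl` share the same core and differ only in the length of the chain on sulfur. In a functional assay on MOLT-3 cells (Homo sapiens) (a lower number here means a stronger inhibitor, a higher number a weaker inhibitor), compound 1 gives 5400 nM. Compound 2 gives no number in this assay, only a limit, > 100000 nM. Among the measured compounds shown here, the one measured step, an at least 18-fold higher number from compound 1 to compound 2 (1.26 log units; beyond the scatter), runs to that limit, (the limit of > 100000 nM in this assay, at which 1 of the 2 values shown sits). Compound 3 `CCCCCCCCCCCCCCCCCCSC[C@H](NC(C)=O)C(=O)CCl` carries pentyl in place of hydrogen on a saturated chain carbon, ten or more bonds along the chain from a sulfur, lengthening the same chain further. Given the limit (the limit of > 100000 nM in this assay, at which 1 of the 2 values shown sits), the step that the limit leaves unreadable from compound 2 to compound 3 is expected to bring no gain. Compound 3 is therefore estimated at 150000 nM, within 60000 nM to 400000 nM, most likely again reported only as a limit.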

Compound 3, half-maximal inhibitory concentration: > 100000 nM
Compound 3 ended at the assay's limit; the forecaster's own chance of this, stated with the estimate: 90%; the middle value does not contradict the limit.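

The step from compound 2 to compound 3 cannot be read, because both stand only at a limit: the limit of > 100000 nM in this assay, at which 2 of the 3 values shown sit.

The compounds shown leave open whether compound 2 and compound 3 differ at all, and how the number changes at chain lengths between those of compound 1 and compound 2.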